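Compound 1 to compound 4: chloro in place of methoxy

The source may hold more compounds than are shown below. What is called first, only, known or untested is meant among the compounds shown, and "the series" means these compounds.

Within the data shown here, in a functional assay on UACC-62 cells (Homo sapiens) for cytotoxicity, read by MTT assay, with a stated time of 6 days (a lower number here means a stronger inhibitor, a higher number a weaker inhibitor), compound 1 (`COc1ccc(NC(=O)SC[C@H](NC(C)=O)C(=O)O)cc1`) gives 75200 nM, the only true number so far. Compound 2 (`CC(=O)N[C@@H](CSC(=O)NCc1ccc(Cl)cc1)C(=O)O`) reads > 200000 nM, which is a limit and not a number. Compound 3 (`COc1ccc(OC)c(NC(=O)SC[C@H](NC(C)=O)C(=O)O)c1`) reads > 200000 nM, again a limit. The rest of the picture is the limit of > 200000 nM in this assay, at which 2 of the 3 values shown sit. Among the measured compounds shown here, no two measured compounds differ in just one place, so the series offers no measured step to work from.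

Compound 4 (`CC(=O)N[C@@H](CSC(=O)Nc1ccc(Cl)cc1)C(=O)O`) has not yet been measured in this assay. It departs from compound 1 at a single place: chloro in place of methoxy on an aromatic carbon. The change is chloro in place of methoxy on an aromatic carbon, para to a large group.

For the measured compounds named here, with no measured step as a guide, the expectation is anchored on compound 1 at 75200 nM. A shift toward weaker inhibition is expected, but one that stays within the usual scatter, and compound 4 may also return only a limit. The expected step is a 1.5-fold higher number from compound 1 to compound 4 (0.17 log units; within the scatter). For compound 4 the estimated value is 110000 nM, with an expected range from 45000 nM to 200000 nM.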

Compound 4, half-maximal inhibitory concentration: 24 nM
Beside the measured number, compound 4's estimate is 4600-fold (3.66 log units) above it; measured number outside the range, below it.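

In this assay, the place on the aromatic ring para to a large group turns out to be highly sensitive to substitution: chloro in place of methoxy gives a 3100-fold lower number from compound 1 to compound 4 (3.50 log units; beyond the scatter). Among these compounds, this is the first one-place comparison, and it shows that exchanging a methoxy (one carbon, one oxygen, one hydrogen-bond acceptor) for a single chlorine atom is enough to move the read-out well beyond the scatter, with the rest of the structure unchanged. Compound 2 and compound 3 remain limits and not numbers, and neither offers a step that can be read: the limit of > 200000 nM in this assay, at which 2 of the 4 values shown sit.

The two groups shown at this place do not settle whether the gain belongs to chloro itself or simply to the absence of methoxy, and a bromo, a methyl, a trifluoromethyl or an amine at the same carbon would help separate those readings. Also open, from the compounds shown here alone, is whether chloro at another carbon of the ring would behave in the same way, and no measured property of either group is available to explain the size of the step.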